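The source may hold more compounds than are shown below. What is called first, only, known or untested is meant among the compounds shown, and "the series" means these compounds.

Series notes. Compound 1 `Nc1scc(CN2CCN(c3ccc(Cl)cc3Cl)CC2)c1C(=O)c1ccc(Cl)cc1` gives -54% in a functional assay on CHO cells with adenosine receptor A1 (Homo sapiens) as the target, read by cAMP accumulation and immunoassay, with a stated time of 6 min, tested at 1 uM; a lower number here means a stronger effect, a higher number a weaker effect of the compound at the concentration tested; compound 2 `Nc1scc(CN2CCN(c3cccc(Cl)c3Cl)CC2)c1C(=O)c1ccc(Cl)cc1` gives -57%; compound 3 `Nc1scc(CN2CCN(c3ccc(F)cc3Cl)CC2)c1C(=O)c1ccc(Cl)cc1` gives -39%, the highest of the three numbers. Both steps that change the aryl group on the ring nitrogen bear on the next step: a number 15 percentage points higher from compound 1 to compound 3 (beyond the scatter), and a number 18 percentage points higher from compound 2 to compound 3 (beyond the scatter), so exchanging substituents on that aryl group has moved the read-out by a modest amount in both cases, though the step of a number 3 percentage points lower from compound 1 to compound 2 (within the scatter) lies within the scatter. Compound 4 `Nc1scc(CN2CCN(c3cccc(C(F)(F)F)c3)CC2)c1C(=O)c1ccc(Cl)cc1` differs from compound 3 by 3-(trifluoromethyl)phenyl in place of 2-chloro-4-fluorophenyl on an amine nitrogen in a ring. Within the data shown here, no measured compound carries a trifluoromethyl group, so the direction is open; a modest step of either sign is plausible. For compound 4 the expected value is -42%, within -65% to -18%, which means an expected step of a number 3 percentage points lower from compound 3 to compound 4 (within the scatter).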

Compound 4, a percentage reported as activity, at one concentration (the size of the read-out at that concentration, not a potency): -72%
Compound 4: middle estimate off by 30 percentage points, on the high side, and the stated range ends above it.
By their numbers in this assay, from the lowest: compound 4; then compounds 2 and 1 (each within the scatter of the next); then compound 3.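

In this assay, changing the aryl group on the ring nitrogen can give a large step, not only the modest ones seen so far (a number 33 percentage points lower from compound 3 to compound 4 (beyond the scatter)). The 3-(trifluoromethyl)phenyl group, which carries no chloro substituent, also goes beyond both dichlorophenyl compounds (a number 15 percentage points lower from compound 2 to compound 4 (beyond the scatter); a number 18 percentage points lower from compound 1 to compound 4 (beyond the scatter)), so compound 4 has the strongest effect of the four at the concentration tested. No evidence on the cause of these steps is available.

Compound 4 changes both the substituent and its place on the aryl group, so the two cannot be separated. As far as these compounds go, how a nitrile or methoxy group would compare on this aryl ring remains open.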